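A few compounds are considered here, and "the series" means these few. Any claim that something is new, unique, unknown or untested is made for them only; others in the source may bear on it.

Measured in an ADME assay on the whole organism for pharmacokinetics, with Rattus norvegicus as the target, at a dose of 1 mg/kg by the intravenous route; a higher number here means faster removal of the compound, a lower number slower removal:
- compound 1 `C[C@@H]1CN(C(=O)C(=O)c2c[nH]c3c(-c4ncco4)ccnc23)CCN1C(=O)c1ccccc1`: 7.4 mL/min/kg
- compound 2 `C[C@@H]1CN(C(=O)C(=O)c2c[nH]c3c(-c4nccs4)ccnc23)CCN1C(=O)c1ccccc1`: 11.2 mL/min/kg

Within the data shown here, compound 2 holds the higher of the two numbers in this assay, but its only neighbour, compound 1, sits within the scatter of it, so no order between the two can be read. Among the measured compounds shown here, the single step available, a 1.5-fold higher number from compound 1 to compound 2 (0.18 log units; within the scatter), exchanges one five-membered aromatic ring for another on the same aromatic carbon of the shared core and leaves clearance where it was.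

Compound 3 `C[C@@H]1CN(C(=O)C(=O)c2c[nH]c3c(-n4nccn4)ccnc23)CCN1C(=O)c1ccccc1` is the next member. It differs from compound 2 by 2H-1,2,3-triazol-2-yl in place of 1,3-thiazol-2-yl on an aromatic carbon. For the measured compounds named here, the change again replaces one five-membered aromatic ring with another at the same carbon, so the step from compound 1 to compound 2 is the only measured comparison that bears on it, and that step stayed within the scatter. Nothing in the series points to a direction, and the expected step of a 1.1-fold lower number from compound 2 to compound 3 (0.05 log units; within the scatter) is therefore taken as none beyond the scatter. Compound 3 is estimated at 10 mL/min/kg in this assay, with a range of 5 mL/min/kg to 20 mL/min/kg.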

Compound 3, clearance: 13.9 mL/min/kg
Compound 3: the middle estimate sits 1.4-fold (0.14 log units) below what was measured; the range from low to high includes it.
By their numbers in this assay, from the lowest: compounds 1, 2 and 3 (each within the scatter of the next).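

In this assay, the carbon opposite the ring nitrogen now carries three different five-membered aromatic rings, and the step of a 1.2-fold higher number from compound 2 to compound 3 (0.09 log units; within the scatter) adds a ring with 3 hetero atoms and no sulfur without leaving the scatter. The step of a 1.9-fold higher number from compound 1 to compound 3 (0.27 log units; within the scatter) links the two compounds not yet directly compared and also stays within the scatter, so across compounds 1, 2 and 3 no exchange among these rings gives a readable difference in clearance, and none of the three goes against this. No supporting data bear on why these rings give this result.

Open, going by these compounds, is whether clearance at this carbon stays in the same band with a group of another kind, such as a primary amine, a carboxylic acid, a morpholine or a longer alkyl chain, since all three groups here are five-membered aromatic rings. Also open, on these data alone, is whether the same holds with an aliphatic acyl group in place of the benzoyl group on the shared core.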